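Chain Extension in the Mirror-Image Series

A few compounds are considered here, and "the series" means these few. Any claim that something is new, unique, unknown or untested is made for them only; others in the source may bear on it.

Measured compounds:
compound 1, `CCCC/C=C/c1ccc(CO[C@@H]2CN[C@@H](CO)C2)cc1`, a functional assay on FL5.12 cells (Mus musculus) for cytotoxicity, read by flow cytometry, with a stated time of 48 h; a higher number here means a weaker inhibitor, a lower number a stronger inhibitor: 5500 nM
compound 2, `CCCCCC/C=C/c1ccc(CO[C@@H]2CN[C@@H](CO)C2)cc1`, this assay: 1400 nM
compound 3, `CCCC/C=C/c1ccc(CO[C@H]2CN[C@H](CO)C2)cc1`, this assay: 5700 nM

Compound 3 sits at the weak end of these three numbers. Its number is indistinguishable from that of compound 1, a step of a 1.0-fold higher number from compound 1 to compound 3 (0.02 log units; within the scatter), and the two share every atom and bond, as the fact that compounds 1 and 3 differ only in the configuration as drawn makes plain. Against compound 2, compound 3 stands further off, beyond the scatter.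

Compound 4, `CCCCCC/C=C/c1ccc(CO[C@H]2CN[C@H](CO)C2)cc1`, has not been measured in this assay. It differs from compound 3 by ethyl in place of hydrogen on a saturated chain carbon, four bonds along the chain from a double-bonded chain carbon.

Among the compounds with values here, one measured step bears directly on this change: the same ethyl for hydrogen exchange carried compound 1 to compound 2 with a step of a 3.9-fold lower number from compound 1 to compound 2 (0.59 log units; beyond the scatter), a modest drop in the number. Since compounds 1 and 3 give the same number and differ only in configuration as drawn, the same change in the mirror-image series is expected to read similarly. Compound 4 is therefore expected to show a step of a 3.8-fold lower number from compound 3 to compound 4 (0.58 log units; beyond the scatter), downward, beyond the scatter.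

The estimated number for compound 4 is 1500 nM, with a range from 700 nM to 3500 nM.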

Compound 4, half-maximal inhibitory concentration: 2400 nM
The estimate for compound 4 lay 1.6-fold (0.20 log units) below the measured number; the range from low to high includes it.
By their numbers in this assay, from the lowest: compounds 2 and 4 (each within the scatter of the next); then compounds 1 and 3 (each within the scatter of the next).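

In this assay the exchange of hydrogen for ethyl at this position also lowers the number on the core of compound 3, a 2.4-fold lower number from compound 3 to compound 4 (0.38 log units; beyond the scatter), so the drop is no longer tied to the single core on which it had first been seen. The size of the step also carries over, and the two readings of this change agree: the same change on two cores in this assay, a 3.9-fold lower number (0.59 log units; beyond the scatter) from compound 1 to compound 2 and a 2.4-fold lower number (0.38 log units; beyond the scatter) from compound 3 to compound 4, 1.7-fold (0.22 log units) apart, within the scatter of two such steps. Within the data shown here, the longer chain likewise shows no separation between the two drawn configurations, a 1.7-fold higher number from compound 2 to compound 4 (0.23 log units; within the scatter), a gap within the scatter, so the match earlier seen only with the shorter chain also holds here: the fact that compounds 2 and 4 differ only in the configuration as drawn.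

The compounds shown leave open whether a longer chain, or an amine or a carboxylic acid in place of the ethyl, would move the number further in either series. They also leave open how a compound with only one of the two saturated ring stereocentres changed would read, as both stereocentres differ together in each pair here, so neither stereocentre can be judged alone.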